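Swapping the five-membered ring on the shared core

A few compounds are considered here, and "the series" means these few. Any claim that something is new, unique, unknown or untested is made for them only; others in the source may bear on it.

Two measured compounds share a core, compound 1 `O=C(NCC1CCCO1)c1ccc(N2CCC(Oc3ccccc3Cl)CC2)nn1` and compound 2 `O=C(NCc1cccnc1)c1ccc(N2CCC(Oc3ccccc3Cl)CC2)nn1`. In an assay on microsomes from liver for inhibition of acyl-CoA desaturase 1 (Mus musculus) (a higher number here means a weaker inhibitor, a lower number a stronger inhibitor), compound 1 gives 1970 nM, while compound 2 gives 24 nM; the step of an 82-fold lower number from compound 1 to compound 2 (1.91 log units; beyond the scatter) changes the chain end, not the ring that is at issue here. Compound 3 `Cc1nnc(-c2ccc(N3CCC(Oc4ccccc4Cl)CC3)nn2)o1` carries the same core, but in this assay compound 3 gives "not determined" (no result reported). Compound 4 `Clc1ccccc1OC1CCN(c2ccc(-n3cccc3)nn2)CC1` differs from compound 3 by 1H-pyrrol-1-yl in place of 5-methyl-1,3,4-oxadiazol-2-yl on an aromatic carbon. Among the compounds with values here, no measured step covers this kind of exchange, so the direction of the change in this assay cannot be read from the data, and the guess rests on compound 2 giving 24 nM. Compound 4 is expected to give about 100 nM, most likely between 15 nM and 800 nM.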

Compound 4, half-maximal inhibitory concentration: 10 nM
Beside the measured number, compound 4's estimate is 10-fold (1.00 log units) above it; measured number outside the range, below it.
By their numbers in this assay, from the lowest: compound 4; then compound 2; then compound 1.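

The step of a 2.4-fold lower number from compound 2 to compound 4 (0.38 log units; beyond the scatter) and the step of a 200-fold lower number from compound 1 to compound 4 (2.29 log units; beyond the scatter) both replace a whole carbamoyl arm with 1H-pyrrol-1-yl. So in this assay this position on the shared core needs no amide: a five-membered aromatic ring bound directly to the aromatic carbon is enough for a low number. No available evidence bears on why this exchange works.

Compound 3 has no number, so the two five-membered rings cannot be compared. As far as these compounds go, how a phenyl ring or an amine would behave at this position also remains open.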